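From 2-fluorophenyl to 4-bromophenyl on an amide-type nitrogen

The source may report more compounds than this note shows. Statements on the series, on what has been measured and on what is new or still open speak of the compounds shown alone.

In a functional assay on OVCAR-5 cells (Homo sapiens) for inhibition, read by CCK-8 assay, with a stated time of 72 h, tested at 10 uM (on this read-out higher numbers stand for more inhibition of growth at the one concentration tested and lower numbers for less inhibition of growth), compound 1 `CN(C)C(=O)c1cc2cnc(Nc3ccc(NC(=O)C4(C(=O)Nc5ccc(Cl)cc5)CC4)cc3)nc2n1C1CCCC1` gives 85.3%, compound 2 `CN(C)C(=O)c1cc2cnc(Nc3ccc(NC(=O)C4(C(=O)Nc5cccc(F)c5)CC4)cc3)nc2n1C1CCCC1` gives 85.6% and compound 3 `CN(C)C(=O)c1cc2cnc(Nc3ccc(NC(=O)C4(C(=O)Nc5ccccc5F)CC4)cc3)nc2n1C1CCCC1` gives 82.6%. Compound 3 thus sits within the scatter of both others. Compound 4 `CN(C)C(=O)c1cc2cnc(Nc3ccc(NC(=O)C4(C(=O)Nc5ccc(Br)cc5)CC4)cc3)nc2n1C1CCCC1` differs from compound 3 as follows: 4-bromophenyl in place of 2-fluorophenyl on an amide-type nitrogen. The closest guide is a number 2.7 percentage points lower from compound 1 to compound 3 (within the scatter), which swaps 4-chlorophenyl for 2-fluorophenyl. The other two measured swaps, a number 0.3 percentage points higher from compound 1 to compound 2 (within the scatter) and a number 3 percentage points lower from compound 2 to compound 3 (within the scatter), are just as small. For the measured compounds named here, no 4-bromophenyl compound has been measured yet, so this remains an extrapolation. The expected change, a number 1.4 percentage points higher from compound 3 to compound 4 (within the scatter), stays within the scatter. For compound 4 the estimate is 84%, with an expected range from 74% to 92%.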

Compound 4, percent growth inhibition at one concentration: 87.8%
For compound 4 the middle estimate is 3.8 percentage points below the measured one, and the stated range covers the measured number.
By their numbers in this assay, from the lowest: compounds 3, 1, 2 and 4 (each within the scatter of the next).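

In this assay, bromo in place of chloro on an aromatic carbon gives a number 2.5 percentage points higher from compound 1 to compound 4 (within the scatter) and the swaps from the two fluorophenyl groups give a number 2.2 percentage points higher from compound 2 to compound 4 (within the scatter) and a number 5.2 percentage points higher from compound 3 to compound 4 (within the scatter) as the remaining steps. This amide-type nitrogen thus carries a bromine-bearing phenyl as well, and this read-out does not separate the four halogen-bearing phenyl groups. Nothing at hand explains this result. From the compounds shown here alone, whether an unsubstituted phenyl, an aminophenyl, a methoxyphenyl or a cyclohexyl group on this nitrogen would fall within the same scatter remains open.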